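The source may report more compounds than this note shows. Statements on the series, on what has been measured and on what is new or still open speak of the compounds shown alone.

Compound 1 `CCCCCCCCCCc1cc2cn([C@H]3C[C@H](O)[C@@H](CO)O3)c(=O)nc2o1` carries a decyl chain on the shared core. In an ADME assay on HEL cells (Homo sapiens) for cytotoxicity, with a stated time of 3 days (on this read-out lower numbers stand for higher toxicity in this test and higher numbers for lower toxicity in this test), compound 1 gives >= 130000 nM, which is a limit of the assay rather than a measured number. Compound 2 `CCCCCc1ccc(-c2cc3cn([C@H]4C[C@H](O)[C@@H](CO)O4)c(=O)nc3o2)cc1` is the other measured member. In this assay compound 2 gives > 1300 nM, also a limit of the assay. Compound 3 `O=c1nc2oc(CCc3ccccc3)cc2cn1[C@H]1C[C@H](O)[C@@H](CO)O1` differs from compound 1 by phenyl in place of octyl on a saturated chain carbon, two bonds along the chain from an aromatic carbon. Among the measured compounds shown here, no step between measured compounds is available, so the change is expected to bring no shift beyond the scatter, an expected step of an at least 1.3-fold lower number from compound 1 to compound 3 (0.11 log units; that floor lies within the scatter). Compound 3 is therefore estimated at 100000 nM, within a range from 20000 nM to 300000 nM.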

Compound 3, minimum cytotoxic concentration: > 560000 nM
Compound 3 ended at the assay's limit; the forecaster's own chance of this, stated with the estimate: 80%; middle value at least 5.6-fold (0.74 log units) away from the limit.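

Compound 1 and compound 3 each give only a limit in this assay, and the step between them cannot be read. The compounds shown leave open at what concentration any of them turns toxic to these cells.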